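The compounds below may be only part of what the source reports. "The series", "measured", "known", "first", "only" and "open" are said of these compounds alone.

Working notes on the series. Compound 1, `O=C(NC(=S)N1CCc2cccc(OCc3ccccc3)c21)c1ccccc1`, gives only a limit in an ADME assay on Huh-7 cells (Homo sapiens) for cytotoxicity (a higher number here means that more compound is tolerated, a lower number that less compound is tolerated), reported as > 50000 nM, and the same limit is the one at which one of the three values sits, see (the limit of > 50000 nM in this assay, at which 1 of the 3 values shown sits). Compound 2, `N#Cc1cccc(C(=O)NC(=S)N2CCc3c(OCCCCCOc4ccc(Cl)cc4)cccc32)c1`, gives 9750 nM in this assay, and compound 3, `O=C(NC(=S)N1CCc2c(OCCCCCOc3ccc(Cl)cc3)cccc21)c1ccc(Cl)cc1`, gives 21700 nM. Between the two numbers, compound 3 stands higher, with a 2.2-fold higher number from compound 2 to compound 3 (0.35 log units; beyond the scatter).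

Compound 4, `O=C(NC(=S)N1CCc2c(OCCCCCOc3ccc(Cl)cc3)cccc21)c1cccnc1`, differs from compound 3 by pyridin-3-yl in place of 4-chlorophenyl on a carbonyl carbon. For the measured compounds named here, the only step measured at this position runs from compound 2 to compound 3 and concerns a different pair of groups; no measured step exchanges a ring carbon for a ring nitrogen here, so no step bears directly on the change. Going by the values given here, the single measured step at the carbonyl carbon was modest, and a step of similar or smaller size is expected for compound 4, in either direction or none beyond the scatter. Compound 4 is expected to give 20000 nM in this assay, within 8000 nM to 50000 nM, which would mean a 1.1-fold lower number from compound 3 to compound 4 (0.04 log units; within the scatter).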

Compound 4, half-maximal cytotoxic concentration: 11100 nM
Compound 4: the middle estimate sits 1.8-fold (0.26 log units) above what was measured, and the stated range covers the measured number.
By their numbers in this assay, from the lowest: compounds 2, 4 and 3 (each within the scatter of the next, the first and the last beyond it). At a limit, above all of these: compound 1.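

With pyridin-3-yl, the group on the carbonyl carbon has now been varied three ways in this assay, and the exchange of 4-chlorophenyl for pyridin-3-yl gives a 2.0-fold lower number from compound 3 to compound 4 (0.29 log units; within the scatter). For the compounds shown here, the exchange of 3-cyanophenyl for pyridin-3-yl gives a 1.1-fold higher number from compound 2 to compound 4 (0.06 log units; within the scatter), so compound 4 lies within the scatter of both neighbours, and the only step beyond the scatter at this position remains a 2.2-fold higher number from compound 2 to compound 3 (0.35 log units; beyond the scatter). Nothing available accounts for these small steps.

From the compounds shown here alone, it remains open whether a non-aromatic group on the carbonyl carbon, such as a piperidine ring, or a carboxylic acid on its aromatic ring, would move the number further than these three aromatic groups do. Also open, going by these compounds, is how a shorter chain in the chlorophenoxy side arm would read in this assay with the carbonyl group held constant.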